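Hydroxy in place of (tert-butyl)amino in the series

This account rests on a few compounds, and the source may have more. Where it says the series, first, only, none or still open, it means among the compounds named here.

Compound 1 `CC(C)(C)NN=C1C(Cl)=C(Cl)C(Cl)=C1Cl` gives > 3000 nM in a functional assay on RPMI-8226 cells (Homo sapiens) for cytotoxicity, read by MTT assay, with a stated time of 48 h (on this read-out lower numbers stand for stronger inhibition and higher numbers for weaker inhibition), and this value is a limit, not a number. Compound 2 `ClC1=C(Cl)C(Cl)=C(Cl)C1=NN(c1ccccc1)c1ccccc1` gives > 3000 nM in this assay and this value is also a limit. Compound 1 therefore stands at the limit of > 3000 nM in this assay, at which 2 of the 2 values shown sit, and the two compounds cannot be placed in any order.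

Compound 3 `ON=C1C(Cl)=C(Cl)C(Cl)=C1Cl` keeps the shared core and differs from compound 1 by a single change, hydroxy in place of (tert-butyl)amino on a double-bonded nitrogen with hydroxy in place of (tert-butyl)amino on a double-bonded nitrogen. Among the compounds with values here, no measured step gives a size for this change. In this assay the expectation is for no step beyond the scatter, with any real shift more likely towards stronger inhibition, since compound 1 has no number to fall from. The expected size is a step that the limit leaves unreadable from compound 1 to compound 3 and this estimate is uncertain on both sides. Compound 3 is estimated at 3500 nM with an expected range from 1000 nM to 10000 nM and a report as a limit is more likely than not.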

Compound 3, half-maximal inhibitory concentration: > 5000 nM
Compound 3: no number, only a limit; the forecaster's own chance of this, stated with the estimate: 65%; middle value at least 1.4-fold (0.15 log units) away from the limit.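

Compound 1 and compound 3 are both reported only as limits in this assay, and no step can be read between them. The compounds shown leave open whether hydroxy in place of (tert-butyl)amino on a double-bonded nitrogen changes inhibition at all, and in which direction any real shift would run.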